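A few compounds are considered here, and "the series" means these few. Any claim that something is new, unique, unknown or untested is made for them only; others in the source may bear on it.

Measured compounds:
compound 1, `O=C(CN1CCN(c2ccc(F)cn2)CC1)Nc1nc2c(o1)CCCC2`: 63%
compound 2, `O=C(CN1CCN(c2cccc(F)c2)CC1)Nc1nc2c(s1)CCCC2`: "not determined" (no result reported)
compound 3, `O=C(CN1CCN(c2ccc(F)cc2)CC1)Nc1nc2ccccc2s1`: "not determined" (no result reported)

In an ADME assay on microsomes from liver (Mus musculus) for metabolic stability, with a stated time of 0.5 h (a lower number here means that less of the compound is left, a higher number that more of the compound is left), compound 1 gives 63%. Among the measured compounds shown here, for compound 2 the entry reads "not determined" (no result reported), and for compound 3 it reads "not determined" (no result reported), so compound 1 holds the only number in this assay and there is no other figure to set it against. Compound 4, `O=C(CN1CCN(c2ccc(F)cc2)CC1)Nc1nc2c(o1)CCCC2`, is still to be measured. It differs from compound 1 in one place: 4-fluorophenyl in place of 5-fluoropyridin-2-yl on an amine nitrogen in a ring. The group that leaves carries one hydrogen-bond acceptor and the group that enters carries none. For the measured compounds named here, with no measured pair showing the effect of such a swap, the step from compound 1 to compound 4 is expected to be small, at most a modest fall, about a number 11 percentage points lower from compound 1 to compound 4 (beyond the scatter). Compound 4 is therefore estimated at 52%, with a range from 30% to 72%.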

Compound 4, percent of the compound remaining in the liver assay: 53%
Compound 4: middle estimate off by 1 percentage points, on the low side; the measured number falls inside the stated range.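

Among the compounds shown here, in the liver assay the first step at this position, 4-fluorophenyl in place of 5-fluoropyridin-2-yl on an amine nitrogen in a ring, gives a number 10 percentage points lower from compound 1 to compound 4 (within the scatter) and so stays within the scatter. In a physicochemical assay for lipophilicity, in phosphate buffer, measured as octanol-water partition, at pH 7.4 (on this read-out lower numbers stand for lower lipophilicity and higher numbers for higher lipophilicity), compound 1 gives 2.7 and compound 4 gives 3, with a number 0.30 log units higher from compound 1 to compound 4 (within the scatter) again showing no change beyond the scatter. Nothing shown here explains either step. The compounds leave open whether a different group on this nitrogen, such as cyclohexyl or pyrimidin-2-yl, would move either read-out beyond the scatter.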